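A second methyl on the phenoxy ring of compound 3

The compounds below may be only part of what the source reports. "The series", "measured", "known", "first", "only" and "open" are said of these compounds alone.

Compound 3 `Cc1ccc(Oc2ccc3nc(COc4cccc(C(=O)O)c4)n(C)c3n2)cc1` gives the highest number of the three in a physicochemical assay for solubility, read by HPLC, measured as thermodynamic solubility, with a stated time of 4 h, at pH 6.8 (on this read-out higher numbers stand for higher solubility and lower numbers for lower solubility), at 33 ug/mL. Compound 2 `Cn1c(COc2cccc(C(=O)O)c2)nc2ccc(Oc3ccc(F)cc3)nc21` gives 11 ug/mL, and compound 1 `Cn1c(COc2cccc(C(=O)O)c2)nc2ccc(Oc3ccc(Cl)c(F)c3)nc21` gives 1.7 ug/mL; the steps of a 6.5-fold higher number from compound 1 to compound 2 (0.81 log units; beyond the scatter), a 19-fold higher number from compound 1 to compound 3 (1.29 log units; beyond the scatter) and a 3.0-fold higher number from compound 2 to compound 3 (0.48 log units; beyond the scatter) all lie beyond the scatter. Compound 4 `Cc1cc(C)cc(Oc2ccc3nc(COc4cccc(C(=O)O)c4)n(C)c3n2)c1` differs from compound 3 by 3,5-dimethylphenyl in place of 4-methylphenyl on an oxygen on an aromatic ring. For the measured compounds named here, no measured step adds a methyl to a ring that already carries one; the nearest comparison is a 3.0-fold higher number from compound 2 to compound 3 (0.48 log units; beyond the scatter), which exchanges one group for another rather than adding a second methyl, so it is only a loose guide. Compound 4 is expected to show a 1.7-fold lower number from compound 3 to compound 4 (0.22 log units; within the scatter). For compound 4 the estimate is 20 ug/mL, expected between 6 ug/mL and 60 ug/mL.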

Compound 4, solubility: 0.5 ug/mL
For compound 4 the middle estimate is 40-fold (1.60 log units) above the measured one; the measured number lies below the stated range.
By their numbers in this assay, from the lowest: compound 4; then compound 1; then compound 2; then compound 3.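

In this assay, the change from 4-methylphenyl to 3,5-dimethylphenyl on the oxygen gives a 66-fold lower number from compound 3 to compound 4 (1.82 log units; beyond the scatter), so one added carbon at this place can move the number more than any earlier step did. The new group also falls short of both halogenated rings, with a 22-fold lower number from compound 2 to compound 4 (1.34 log units; beyond the scatter) and a 3.4-fold lower number from compound 1 to compound 4 (0.53 log units; beyond the scatter), which makes compound 4 the lowest of the four. Nothing shown here accounts for the drop. The compounds shown leave open whether the number follows the count of methyl groups or their places on the ring, and how a methoxy group or an amine at this ring would read in this assay.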